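Bromoacrylamide series: benzyl to methoxyphenyl swap on the core

The source may report more compounds than this note shows. Statements on the series, on what has been measured and on what is new or still open speak of the compounds shown alone.

Three compounds of this series have numbers in a functional assay on L1210 cells (Mus musculus) for inhibition, read by cell counting, with a stated time of 2 days; a higher number here means a weaker inhibitor, a lower number a stronger inhibitor. Compound 1 `C=C(Br)C(=O)Nc1cccc(-c2cn3nc(Cc4ccccc4)sc3n2)c1` gives 3000 nM, the lowest of the three. Compound 2 `Nc1cccc(-c2cn3c(-c4ccc(Cl)cc4)csc3n2)c1` gives 22000 nM and compound 3 `COc1cccc(Cc2nn3cc(-c4cccc(N)c4)nc3s2)c1` gives 21000 nM; both stand higher than compound 1 by gaps that lie beyond the scatter, and the two of them lie within the scatter of each other. Among the compounds with values here, no two of the measured compounds differ in only one place, so no single step has been measured yet.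

Compound 4 `C=C(Br)C(=O)Nc1cccc(-c2cn3nc(-c4ccc(OC)cc4)sc3n2)c1` is the untested compound. It differs from compound 1 only in one place: 4-methoxyphenyl in place of benzyl on an aromatic carbon. The change keeps the bromoacrylamide and the shared core of compound 1 and alters only the group on the five-membered ring. Within the data shown here, nothing among the measured compounds isolates this change, so no size or direction is known for it; the expectation for the step from compound 1 to compound 4 is none beyond the scatter, no change at the digits printed from compound 1 to compound 4 (within the scatter). Compound 4 is therefore estimated at 3000 nM, with a range from 1000 nM to 10000 nM.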

Compound 4, half-maximal inhibitory concentration: 940 nM
Compound 4: middle estimate off by 3.2-fold (0.50 log units), on the high side; the measured number lies below the stated range.
By their numbers in this assay, from the lowest: compound 4; then compound 1; then compounds 3 and 2 (each within the scatter of the next).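

In this assay, within the data shown here, the group on this aromatic carbon of the five-membered ring proves able to move the read-out with the bromoacrylamide and the shared core held fixed: 4-methoxyphenyl in place of benzyl gives a 3.2-fold lower number from compound 1 to compound 4 (0.50 log units; beyond the scatter), the first single-place step. This one step swaps two things together, the carbon link of benzyl to its ring and the methoxy group with its hydrogen-bond acceptor, so it does not assign the shift to either. No measurement of any property accompanies the step, so nothing here accounts for the shift.

Plain phenyl and 4-methoxybenzyl at this carbon would separate those two parts of the swap. As far as these compounds go, whether an amine, a carboxylic acid or a longer alkyl chain is accepted at this carbon remains open.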